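This account rests on a few compounds, and the source may have more. Where it says the series, first, only, none or still open, it means among the compounds named here.

Measured in an assay on T-REx-293 cells for inhibition of potassium channel subfamily T member 1 (Homo sapiens), read by patch clamp (a higher number here means a weaker inhibitor, a lower number a stronger inhibitor), so far:

- compound 1 `Cc1cccc(-c2noc(C(C)NC(=O)c3cc(C4CC4)nn3C)n2)c1` gives 1880 nM
- compound 2 `Cc1cc(-c2noc([C@H](C)NC(=O)c3cc(C(F)(F)F)nn3C)n2)ccn1` gives 165 nM

Compound 2 stands with the lowest number of the two; the nearest, compound 1, sits higher by a gap beyond the scatter. Going by the values given here, compound 1 and compound 2 differ in more than one place, so the two values show only that compound 2 is the stronger inhibitor here, not which change carries the difference.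

Compound 3 `C[C@H](NC(=O)c1cc(C(F)(F)F)nn1C)c1nc(-c2cnn(C)c2)no1` is not yet measured. It differs from compound 2 by 1-methyl-1H-pyrazol-4-yl in place of 2-methylpyridin-4-yl on an aromatic carbon. Among the compounds with values here, no single-point step between measured compounds is known, so the size of this change can only be guessed. Exchanging one aromatic ring for a smaller one on the shared core is expected to cost some potency, a step in this assay that is modest and at the edge of the scatter rather than far beyond it. Compound 3 is therefore expected to come in at 400 nM, within 120 nM to 1500 nM, an expected step of a 2.4-fold higher number from compound 2 to compound 3 (0.38 log units; beyond the scatter).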

Compound 3, half-maximal inhibitory concentration: 2640 nM
Compound 3: middle estimate off by 6.6-fold (0.82 log units), on the low side, and the stated range ends below it.
By their numbers in this assay, from the lowest: compound 2; then compounds 1 and 3 (each within the scatter of the next).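

In this assay, going by these compounds alone, the change at this position gives a 16-fold higher number from compound 2 to compound 3 (1.20 log units; beyond the scatter), the first step that can be tied to a single place. With the rest of compound 2 held fixed, 1-methyl-1H-pyrazol-4-yl in place of 2-methylpyridin-4-yl on this aromatic carbon is enough to lose much of the inhibition, which the comparison of compound 1 with compound 2, differing in more than one place, could not show. No measurement at hand accounts for this loss.

Within the data shown here, with only two groups compared here, it remains open whether the step follows from the ring size, the number of ring nitrogens or the placement of the methyl. Phenyl, pyridin-4-yl without the methyl and 1-methyl-1H-pyrazol-3-yl would help separate these, and the effect of cyclopropyl against trifluoromethyl cannot yet be read.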